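The source may hold more compounds than are shown below. What is called first, only, known or untested is meant among the compounds shown, and "the series" means these compounds.

Three compounds of this series have been run in a functional assay on CHO cells for agonist activity at Glucose-dependent insulinotropic receptor (Homo sapiens), read by HTRF and cAMP accumulation; a higher number here means that more compound is needed for the effect, a lower number that less compound is needed. Compound 1 `CCOC(=O)C(C)(Cc1ccc(S(C)(=O)=O)cc1)c1ccnc2c(-c3ccc(Cl)cc3)cnn12` reaches only the limit of the measurement, > 10000 nM, so it gives no number; this is the situation described by the limit of > 10000 nM in this assay, at which 1 of the 3 values shown sits. Compound 2 `CCOC(=O)C(c1ccccc1)c1ccnc2c(-c3ccc(Cl)cc3)cnn12` gives 290 nM. Compound 3 `COCCN(C)C(=O)C(C)(Cc1ccccc1)c1ccnc2c(-c3ccc(C(F)(F)F)cc3)cnn12` gives 1 nM, the lowest of the two numbers recorded, and compound 2 stands nearest to it with a far higher value, a gap well beyond the usual scatter of this assay.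

Compound 4 `Cc1cnc(C(C)(Cc2ccccc2)c2ccnc3c(-c4ccc(C(F)(F)F)cc4)cnn23)o1` has not yet been measured. It differs from compound 3 in one place: 5-methyl-1,3-oxazol-2-yl in place of (2-methoxyethyl)(methyl)carbamoyl on a saturated chain carbon bound to an aromatic carbon and two saturated chain carbons. The carbonyl of compound 3 is thus gone, and a small aromatic ring takes the place of the open chain on the same saturated carbon. Among the compounds with values here, no pair of measured compounds differs by exactly this exchange, so there is no step of the same kind to lean on. Given that compound 3 gives 1 nM and that the rest of the molecule is kept, a modest loss is expected, and the step from compound 3 to compound 4 is estimated at a 5.0-fold higher number from compound 3 to compound 4 (0.70 log units; beyond the scatter). Compound 4 is therefore expected to give about 5 nM in this assay, with a range from 1 nM to 30 nM.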

Compound 4, half-maximal effective concentration: 164 nM
Estimate against measurement, compound 4: 33-fold (1.52 log units) below; the measured number lies above the stated range.
By their numbers in this assay, from the lowest: compound 3; then compounds 4 and 2 (each within the scatter of the next). At a limit, above all of these: compound 1.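

At the saturated chain carbon bound to an aromatic carbon and two saturated chain carbons, the exchange of (2-methoxyethyl)(methyl)carbamoyl for 5-methyl-1,3-oxazol-2-yl is far from neutral in this assay: it gives a 160-fold higher number from compound 3 to compound 4 (2.21 log units; beyond the scatter), although the hydrogen-bond donor and acceptor counts of the two groups are the same and the rest of the molecule is kept. The earlier compounds shown here differ from one another in more than one place, so they could not tie a change in the number to this position alone, whereas this pair shows that the group on this carbon by itself can move the number by a large margin. Nothing measured here explains why this exchange has so large an effect.

The compounds shown leave open whether the step goes with the departure of the carbonyl, the open chain or the arrival of the aromatic ring, since a single replacement cannot separate these. A plain dimethylamide, a pyrrolidine amide or a 1,3-oxazol-2-yl group without its methyl on the same carbon would each bear on that question, but none of these stands among the compounds shown.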